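A few compounds are considered here, and "the series" means these few. Any claim that something is new, unique, unknown or untested is made for them only; others in the source may bear on it.

Compound 1 `COc1ccc(/C=N/c2c(C)n(C)n(-c3ccccc3)c2=O)cc1OC`: in a functional assay on P388 cells (Mus musculus) for cytotoxicity, read by MTT assay, with a stated time of 72 h (on this read-out higher numbers stand for weaker inhibition and lower numbers for stronger inhibition), compound 1 gives 141000000 nM.
Compound 2 `COc1ccccc1/C=N/c1c(C)n(C)n(-c2ccccc2)c1=O`: in this assay compound 2 gives 229000000 nM.
Compound 3 `Cc1c(/N=C/c2ccccc2)c(=O)n(-c2ccccc2)n1C`: in this assay compound 3 gives 240000000 nM.

All three share one core; the difference between compound 1 and compound 3 is not broken down here. From compound 3 to compound 2 the change is methoxy in place of hydrogen on an aromatic carbon, and the step it made was a 1.0-fold lower number from compound 3 to compound 2 (0.02 log units; within the scatter). Compound 4 `COc1cc(/C=N/c2c(C)n(C)n(-c3ccccc3)c2=O)cc(OC)c1OC` has not yet been measured; from compound 1 it differs by methoxy in place of hydrogen on an aromatic carbon. This is the same kind of change, but the place is not the same: in compound 2 the entering group sits ortho to a large group, whereas in compound 4 it sits ortho to a methoxy group, meta to a large group and meta to a methoxy group. A small step is expected from compound 1 to compound 4, a 1.1-fold lower number from compound 1 to compound 4 (0.04 log units; within the scatter), because a 1.0-fold lower number from compound 3 to compound 2 (0.02 log units; within the scatter) stayed within the scatter. Compound 4 is therefore estimated at 130000000 nM, between 60000000 nM and 280000000 nM.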

Compound 4, half-maximal inhibitory concentration: 501000000 nM
Compound 4: middle estimate off by 3.9-fold (0.59 log units), on the low side, and the stated range ends below it.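

In this assay, putting a methoxy group in place of a hydrogen gave a 3.6-fold higher number from compound 1 to compound 4 (0.55 log units; beyond the scatter) and so went with weaker inhibition. The same swap did not carry over unchanged from one core to the other, and the two steps differ by more than the usual scatter: the same change on two cores in this assay, a 1.0-fold lower number (0.02 log units; within the scatter) from compound 3 to compound 2 and a 3.6-fold higher number (0.55 log units; beyond the scatter) from compound 1 to compound 4, 3.7-fold (0.57 log units) apart, beyond the scatter of two such steps. Among the compounds shown here, with only one pair on each side, this does not show whether the gap comes from the groups around the new methoxy or from the rest of the molecule, and it gives no rule for other compounds.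

As far as these compounds go, whether another group at this place, such as an amine, a carboxylic acid or a longer chain, would shift the number in the same way remains open. The compounds shown also leave open how a methoxy group entering elsewhere on this ring would behave.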